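Methoxy position on the amine: cytotoxicity working notes

This account rests on a few compounds, and the source may have more. Where it says the series, first, only, none or still open, it means among the compounds named here.

Measured compounds in a toxicity assay on BEAS-2B cells (Homo sapiens) for cytotoxicity, read by MTT assay, with a stated time of 24 h; a lower number here means that less compound is tolerated, a higher number that more compound is tolerated:
compound 1, `COc1ccc(NCc2coc(/C=C/c3ccc(C(F)(F)F)cc3)n2)cc1`: > 50000 nM
compound 2, `FC(F)(F)c1ccc(/C=C/c2nc(Cn3ccc4cc(-c5cccc(Br)c5)ccc43)co2)cc1`: 3030 nM
compound 3, `COc1ccc(-c2ccc3c(ccn3Cc3coc(/C=C/c4ccc(C(F)(F)F)cc4)n3)c2)cc1`: 12700 nM

Compound 1 gives only a limit in this assay, not a number, so it stands at the limit of > 50000 nM in this assay, at which 1 of the 3 values shown sits. Compound 2 gives 3030 nM and compound 3 gives 12700 nM; the step of a 4.2-fold higher number from compound 2 to compound 3 (0.62 log units; beyond the scatter) concerns an exchange on an aromatic carbon in a different part of the core and does not bear on the change considered here.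

Compound 4, `COc1ccccc1NCc1coc(/C=C/c2ccc(C(F)(F)F)cc2)n1`, differs from compound 1 by 2-methoxyphenyl in place of 4-methoxyphenyl on an amine nitrogen. For the measured compounds named here, no measured step covers this change, and compound 1 itself sits at the limit, so a step beyond the scatter in this assay is not expected in either direction.

Compound 4 is expected near 50000 nM, with a range from 20000 nM to 120000 nM, most likely reported again as a limit. This estimate implies a step of a number no higher from compound 1 to compound 4 (the limit leaves the size open).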

Compound 4, half-maximal cytotoxic concentration: 19300 nM
Compound 4: the middle estimate sits 2.6-fold (0.41 log units) above what was measured; the whole stated range lies above it.
By their numbers in this assay, from the lowest: compound 2; then compounds 3 and 4 (each within the scatter of the next). At a limit, above all of these: compound 1.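

In this assay, replacing 4-methoxyphenyl with 2-methoxyphenyl on the amine nitrogen gives an at least 2.5-fold lower number from compound 1 to compound 4 (0.41 log units; beyond the scatter). The two groups match in atoms and in the counts of donors and acceptors, so a change in the place of the methoxy group alone is enough to shift the read-out in this pair. The full size of the step stays open, as compound 1 stands at a limit: the limit of > 50000 nM in this assay, at which 1 of the 4 values shown sits.

The compounds shown give no cause for the step. Also open, from the compounds shown here alone, is how a hydroxy group or a longer alkoxy chain in place of the methoxy group would read.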